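The source may report more compounds than this note shows. Statements on the series, on what has been measured and on what is new or still open speak of the compounds shown alone.

Compound 2 `O=C(O)c1cccc([C@H]2C[C@](OCCO)(c3ccc(OCc4c(-c5c(Cl)cccc5Cl)noc4C4CC4)cc3Cl)C2)c1` gives the highest of the two numbers in an assay on isolated protein for agonist activity at Bile acid receptor (Homo sapiens), read by FRET (on this read-out higher numbers stand for an effect only at larger amounts of compound and lower numbers for an effect already at smaller amounts), namely 373 nM; its nearest neighbour is compound 1 `CCO[C@]1(c2ccc(OCc3c(-c4c(Cl)cccc4Cl)noc3C3CC3)cc2Cl)C[C@H](c2cccc(C(=O)O)c2)C1`, which in this assay gives 277 nM, so the two stand within the scatter of each other. Among the compounds with values here, the one measured step, a 1.3-fold higher number from compound 1 to compound 2 (0.13 log units; within the scatter), shows that attaching a hydroxy to the ethoxy chain changed little. The unmeasured compound 3 `CO[C@]1(c2ccc(OCc3c(-c4c(Cl)cccc4Cl)noc3C3CC3)cc2Cl)C[C@H](c2cccc(C(=O)O)c2)C1` differs from compound 2 by hydrogen in place of hydroxymethyl on a saturated chain carbon bound to an oxygen on a saturated carbon, that is, the 2-hydroxyethoxy becomes a methoxy. This removal is not the reverse of the measured step, since compound 1 keeps the ethyl; the data therefore speak only indirectly to it. Because the step of a 1.3-fold higher number from compound 1 to compound 2 (0.13 log units; within the scatter) was within the scatter, the step of a 1.1-fold lower number from compound 2 to compound 3 (0.05 log units; within the scatter) is expected to be small, with no clear direction beyond the scatter. Compound 3 is estimated at 330 nM in this assay, with a range from 150 nM to 750 nM.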

Compound 3, half-maximal effective concentration: 79 nM
Compound 3: the middle estimate sits 4.2-fold (0.62 log units) above what was measured; measured number outside the range, below it.
By their numbers in this assay, from the lowest: compound 3; then compounds 1 and 2 (each within the scatter of the next).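

The chain on this oxygen matters more than the earlier pair suggested, with a 4.7-fold lower number from compound 2 to compound 3 (0.67 log units; beyond the scatter) and a 3.5-fold lower number from compound 1 to compound 3 (0.54 log units; beyond the scatter) in this assay both printed as beyond the scatter. Compounds 1 and 2 stand within the scatter of each other, so adding a hydroxy to the ethoxy chain made little difference, whereas shortening either chain to methoxy gave a modest drop in the number. No supporting measurement accompanies these values, so the data offer no explanation for the shift.

On these data alone, it remains open whether the number would fall further with a free hydroxy in place of the methoxy, or rise again with a longer chain such as propoxy. Also open, as far as these compounds go, is whether an amine at the end of the ethoxy chain would behave as the hydroxy does.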